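From trifluoromethyl to methoxycarbonyl: an untested swap

The compounds below may be only part of what the source reports. "The series", "measured", "known", "first", "only" and "open" are said of these compounds alone.

Compound 1 `Cc1c(C(=O)Nc2ccc(Oc3ncnc4[nH]cc(-c5ccccc5)c34)c(F)c2)c(=O)c2ccc(Cl)cc2n1C`: > 10000 nM
Compound 2 `Cc1c(C(=O)Nc2ccc(Oc3ncnc4[nH]cc(-c5ccccc5)c34)c(F)c2)c(=O)c2cc(C(F)(F)F)ccc2n1C`: 150 nM

Both compounds were tested in an assay on isolated protein for inhibition of tyrosine-protein kinase receptor UFO (Homo sapiens), read by FRET and Z'-LYTE, with a stated time of 1.5 h; on this read-out lower numbers stand for stronger inhibition and higher numbers for weaker inhibition. For compound 1 the result is not a number but a limit, namely (the limit of > 10000 nM in this assay, at which 1 of the 2 values shown sits). Compound 2 gives 150 nM in this assay, the only numerical result among the two. Compound 1 and compound 2 differ from each other in more than one place, so their two results are simply set side by side here and no single change can be read from them.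

Compound 3 `COC(=O)c1ccc2c(c1)c(=O)c(C(=O)Nc1ccc(Oc3ncnc4[nH]cc(-c5ccccc5)c34)c(F)c1)c(C)n2C` has not yet been measured. It differs from compound 2 by methoxycarbonyl in place of trifluoromethyl on an aromatic carbon. Among the compounds with values here, no measured pair shows a swap of this kind, so the direction is uncertain. The expected shift is modest, toward weaker inhibition: a 2.0-fold higher number from compound 2 to compound 3 (0.30 log units; within the scatter). Compound 3 is therefore estimated to give 300 nM in this assay, with a range from 80 nM to 1500 nM.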

Compound 3, half-maximal inhibitory concentration: > 10000 nM
Compound 3: no number, only a limit (the forecaster's own chance of this, stated with the estimate: 10%); middle value at least 33-fold (1.52 log units) away from the limit.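

Until now no single change could be read, and this pair supplies the first: in this assay, methoxycarbonyl in place of trifluoromethyl on an aromatic carbon gives an at least 66-fold higher number from compound 2 to compound 3 (1.82 log units; beyond the scatter), a step beyond the scatter. The two groups have the same count of heavy atoms, yet this position clearly does not accept both alike, so heavy-atom count alone does not settle what can sit here. The result for compound 3 is a limit and not a number, and another compound shown shares it: the limit of > 10000 nM in this assay, at which 2 of the 3 values shown sit.

The compounds shown leave open how far compound 3 lies past that limit and which part of methoxycarbonyl goes with the loss of inhibition. A nitrile or a carboxylic acid on the same aromatic carbon would give further comparisons with trifluoromethyl.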